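Chloro-to-methyl swap on the benzyl group, with and without carbamate

A few compounds are considered here, and "the series" means these few. Any claim that something is new, unique, unknown or untested is made for them only; others in the source may bear on it.

Measured so far:
- compound 1, `O=C(OCc1ccccc1)N1CCN(C(=S)SCc2cn(Cc3ccc(Cl)cc3)nn2)CC1`: > 128000 nM
- compound 2, `Cc1ccc(Cn2cc(CSC(=S)N3CCN(C(=O)OCc4ccccc4)CC3)nn2)cc1`: 32600 nM
- compound 3, `S=C(SCc1cn(Cc2ccc(Cl)cc2)nn1)N1CCNCC1`: > 128000 nM

In a functional assay on ECa-109 cells (Homo sapiens) for inhibition, read by MTT assay, with a stated time of 72 h (a higher number here means a weaker inhibitor, a lower number a stronger inhibitor), compound 1 gives only a limit, > 128000 nM. Compound 3 likewise gives only a limit, > 128000 nM. Compound 2 gives a number in this assay, 32600 nM. The change methyl in place of chloro on an aromatic carbon made an at least 3.9-fold lower number from compound 1 to compound 2 (0.59 log units; beyond the scatter). The two cores differ by hydrogen in place of benzyloxycarbonyl on an amine nitrogen in a ring, and a step that the two limits leave unreadable from compound 1 to compound 3, because the limit of > 128000 nM in this assay, at which 2 of the 3 values shown sit, leaves no room to read it.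

Compound 4, `Cc1ccc(Cn2cc(CSC(=S)N3CCNCC3)nn2)cc1`, is not yet measured. It differs from compound 3 by methyl in place of chloro on an aromatic carbon, the same change as from compound 1 to compound 2. Starting from the limit of compound 3, the step of an at least 1.2-fold lower number from compound 3 to compound 4 (0.10 log units; that floor lies within the scatter) is expected to be of similar size to an at least 3.9-fold lower number from compound 1 to compound 2 (0.59 log units; beyond the scatter). Compound 4 is therefore estimated at 100000 nM, between 30000 nM and 300000 nM, with a fair chance that only a limit is reported.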

Compound 4, half-maximal inhibitory concentration: > 128000 nM
Compound 4 was reported as a limit; the forecaster's own chance of this, stated with the estimate: 50%; at least 1.2-fold (0.10 log units) between middle value and limit.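

In this assay compound 4 gives only a limit, > 128000 nM. The methyl-for-chloro change therefore cannot be read on the core without benzyloxycarbonyl, because compound 3 and compound 4 both stand at a limit: the limit of > 128000 nM in this assay, at which 3 of the 4 values shown sit. So the lower number seen on the benzyloxycarbonyl core is neither confirmed nor contradicted on the second core, while hydrogen in place of benzyloxycarbonyl in the methyl pair gives an at least 3.9-fold higher number from compound 2 to compound 4 (0.59 log units; beyond the scatter).

The compounds shown leave open how far the methyl-for-chloro step would carry over on a core where both partners give a number. They also leave open whether a methoxy group on that aromatic carbon, or an acetyl group in place of benzyloxycarbonyl on the ring nitrogen, would give a measurable value.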